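Iodo to methyl on the phenoxy ring of compound 2

This account rests on a few compounds, and the source may have more. Where it says the series, first, only, none or still open, it means among the compounds named here.

compound 1 `Cc1nn(C)c(Oc2cccc(F)c2)c1/C=N\CCCCCCOc1cc2oc(=O)cc(C)c2cc1Cl` — > 25000 nM
compound 2 `Cc1nn(C)c(Oc2ccc(I)cc2)c1/C=N\CCCCCCOc1cc2oc(=O)cc(C)c2cc1Cl` — 14200 nM

Within the data shown here, in a functional assay on HepG2 cells (Homo sapiens) for antiproliferative activity, read by MTT assay, with a stated time of 72 h (a higher number here means a weaker inhibitor, a lower number a stronger inhibitor), compound 2 holds the only numeric value. Compound 1 reached only a limit of the assay, (the limit of > 25000 nM in this assay, at which 1 of the 2 values shown sits). Compound 3 `Cc1ccc(Oc2c(/C=N\CCCCCCOc3cc4oc(=O)cc(C)c4cc3Cl)c(C)nn2C)cc1` differs from compound 2 by methyl in place of iodo on an aromatic carbon. Among the measured compounds shown here, the sole measured step, an at least 1.7-fold lower number from compound 1 to compound 2 (0.24 log units; that floor lies within the scatter), changes a different ring substituent and stays within the scatter, so it offers weak guidance. A step of a 1.3-fold higher number from compound 2 to compound 3 (0.10 log units; within the scatter) is therefore expected, none beyond the scatter. Compound 3 is estimated at 18000 nM in this assay, with a range from 7000 nM to 40000 nM.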

Compound 3, half-maximal inhibitory concentration: 20700 nM
The estimate for compound 3 lay 1.2-fold (0.06 log units) below the measured number; low and high end bracket the measured number.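

In this assay, methyl in place of iodo on this aromatic carbon gives a 1.5-fold higher number from compound 2 to compound 3 (0.16 log units; within the scatter), so the assay does not separate these two groups here. The comparison with the 3-fluorophenyl compound gives an at least 1.2-fold lower number from compound 1 to compound 3 (0.08 log units; that floor lies within the scatter), which also settles no order. Compound 1 stands at a limit of the assay rather than at a number: the limit of > 25000 nM in this assay, at which 1 of the 3 values shown sits.

As far as these compounds go, whether an amine or a carboxylic acid on this aromatic carbon would carry the number beyond the scatter remains open. So does the effect of a longer chain at this place.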